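Methyl shift from compound 3 to compound 4

The source may hold more compounds than are shown below. What is called first, only, known or untested is meant among the compounds shown, and "the series" means these compounds.

Measured in an ADME assay on MT4 cells (Homo sapiens) for cytotoxicity, read by MTT assay, with a stated time of 5 days; a lower number here means that less compound is tolerated, a higher number that more compound is tolerated:
- compound 1 `N#Cc1ccc(Nc2nccc(OCc3cccnc3)n2)cc1`: 6400 nM
- compound 2 `N#Cc1ccc(Nc2nccc(OCc3ccccc3F)n2)cc1`: 151000 nM
- compound 3 `Cc1ccccc1COc1ccnc(Nc2ccc(C#N)cc2)n1`: 12000 nM

Compound 3 lies in a close pair, with one distant value: a 1.9-fold higher number from compound 1 to compound 3 (0.27 log units; within the scatter), against a 13-fold lower number from compound 2 to compound 3 (1.10 log units; beyond the scatter). Compound 4 `Cc1ccc(COc2ccnc(Nc3ccc(C#N)cc3)n2)cc1` has 4-methylphenyl in place of 2-methylphenyl on a saturated chain carbon bound to an oxygen on an aromatic ring. Among the measured compounds shown here, no measured step moves a methyl group. Changes at this place can be large, as in a 24-fold higher number from compound 1 to compound 2 (1.37 log units; beyond the scatter), but the step of a 1.9-fold higher number from compound 1 to compound 3 (0.27 log units; within the scatter) is not, and only compound 2 stands apart. No step beyond the scatter is therefore expected, and the estimate is a 1.2-fold higher number from compound 3 to compound 4 (0.07 log units; within the scatter). For compound 4 the expected value is 14000 nM, with an estimated range of 5000 nM to 50000 nM.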

Compound 4, half-maximal cytotoxic concentration: 81000 nM
Beside the measured number, compound 4's estimate is 5.8-fold (0.76 log units) below it, and the stated range ends below it.
By their numbers in this assay, from the lowest: compounds 1 and 3 (each within the scatter of the next); then compounds 4 and 2 (each within the scatter of the next).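

In this assay, moving the methyl from 2-methylphenyl to 4-methylphenyl on the saturated chain carbon is a real change (a 6.8-fold higher number from compound 3 to compound 4 (0.83 log units; beyond the scatter)), so the same carbon count does not fix the value at this position. The 4-methylphenyl of compound 4 cannot be told apart from the 2-fluorophenyl of compound 2 (a 1.9-fold lower number from compound 2 to compound 4 (0.27 log units; within the scatter)), yet stands well clear of the pyridin-3-yl of compound 1 (a 13-fold higher number from compound 1 to compound 4 (1.10 log units; beyond the scatter)). Nothing measured accounts for the methyl shift. Open, from the compounds shown here alone, is whether 4-fluorophenyl shows a similar gap from 2-fluorophenyl, and where 4-methoxyphenyl would fall.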